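Swapping a thiophene for a furan on a pyridine core

The compounds below may be only part of what the source reports. "The series", "measured", "known", "first", "only" and "open" are said of these compounds alone.

Of the compounds shown here, two sharing one core have been tested in a functional assay on T47D cells (Homo sapiens) for cytotoxicity, read by CCK-8 assay; a lower number here means a stronger inhibitor, a higher number a weaker inhibitor. Compound 1 `Oc1ccc(-c2cc(-c3ccsc3)cc(-c3cccc(O)c3)n2)cc1` gives 760 nM. For the measured compounds named here, compound 2 `Oc1ccc(-c2cc(-c3ccsc3)cc(-c3ccc(O)cc3)n2)cc1` gives 1770 nM, which is the higher of the two numbers; the only measured step, a 2.3-fold higher number from compound 1 to compound 2 (0.37 log units; beyond the scatter), concerns the position of a hydroxyl group and nothing else. Compound 3 `Oc1ccc(-c2cc(-c3ccoc3)cc(-c3ccc(O)cc3)n2)cc1` has not yet been measured. It differs from compound 2 in one place: furan-3-yl in place of thiophen-3-yl on an aromatic carbon. Going by the values given here, no measured step touches this part of the molecule, so nothing in the data so far speaks for or against a change in this assay. The step from compound 2 to compound 3 is therefore expected to stay within the scatter, and the expected step of a 1.0-fold higher number from compound 2 to compound 3 (0.01 log units; within the scatter) is taken as none beyond it. Compound 3 is expected to give about 1800 nM, with a range from 700 nM to 4500 nM.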

Compound 3, half-maximal inhibitory concentration: 3460 nM
Compound 3: the middle estimate sits 1.9-fold (0.28 log units) below what was measured; low and high end bracket the measured number.
By their numbers in this assay, from the lowest: compound 1; then compounds 2 and 3 (each within the scatter of the next).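

In this assay, the change at the position opposite the ring nitrogen gives a 2.0-fold higher number from compound 2 to compound 3 (0.29 log units; within the scatter), and this is the only view of that position among the compounds shown. Thiophen-3-yl and furan-3-yl differ by one hetero atom, sulfur against oxygen, in a five-membered aromatic ring, and on this result compound 2 and compound 3 cannot be told apart in this assay, so the ring's sulfur is not shown to be needed here. No outside measurement is available to explain this result.

Going by these compounds, it remains open whether the same swap would read alike with the 3-hydroxyphenyl group of compound 1 in place. Also open, on these data alone, is how a clearly different group at this position, such as an amine, a carboxylic acid or a longer chain, would affect the number.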